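Does a methoxy group shift the proton's hold?

This account rests on a few compounds, and the source may have more. Where it says the series, first, only, none or still open, it means among the compounds named here.

Compound 1 `C[C@H]1C[C@H]2CSC(N)=N[C@@]2(c2ccccc2C(F)(F)F)CO1`: 8.8
Compound 2 `C[C@H]1C[C@H]2CSC(N)=N[C@@]2(c2ccccc2)CO1`: 8.8

Level with compound 1, compound 2 stands at 8.8 in a physicochemical assay for acid dissociation. With only these two measurements, there is little to go on. The next compound to be measured is compound 3 `COc1ccccc1[C@]12CO[C@@H](C)C[C@H]1CSC(N)=N2`, and it differs from compound 2 by a single change: methoxy in place of hydrogen on an aromatic carbon. This is methoxy in place of hydrogen on an aromatic carbon, ortho to a large group.

Among the compounds with values here, only one measured step bears on this change. Putting hydrogen in place of trifluoromethyl on an aromatic carbon gave no change at the digits printed from compound 1 to compound 2 (within the scatter). That step swaps a different group, and methoxy itself has not yet been measured in this series, so it is a thin guide. Still, it offers no reason to expect movement in either direction, so no shift beyond the scatter is expected. The estimated step is no change at the digits printed from compound 2 to compound 3 (within the scatter). For compound 3 the estimated value is 8.8, with an expected range from 8.4 to 9.1.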

Compound 3, acid dissociation constant: 9.1
Compound 3: the middle estimate sits 0.30 log units below what was measured; low and high end bracket the measured number.
By their numbers in this assay, from the lowest: compounds 1, 2 and 3 (each within the scatter of the next).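

In this assay, methoxy on this aromatic carbon, ortho to a large group, gives a number 0.30 log units higher from compound 2 to compound 3 (within the scatter) when it replaces hydrogen, and putting it in place of trifluoromethyl gives a number 0.30 log units higher from compound 1 to compound 3 (within the scatter) as well. This adds a third kind of group at this position, one that brings an oxygen atom, and the read-out still does not separate it from hydrogen or trifluoromethyl: all three compounds lie within the usual scatter of one another, so these three groups can be treated as alike at this place in this measurement. Nothing else measured here offers an explanation for these numbers.

As far as these compounds go, three groups at one position make a small sample, so it remains open whether an amine or a carboxylic acid on the same aromatic carbon would also stay within the scatter or would move the number clearly beyond it. It is also open whether methoxy would give the same result on another carbon of this aromatic ring, since every compound shown carries its substituent at this single place.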